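From 4-chlorobenzyl to 3-fluorobenzyl: Compound 3 to Compound 4

The source may report more compounds than this note shows. Statements on the series, on what has been measured and on what is new or still open speak of the compounds shown alone.

In a functional assay on MDA-MB-231 cells (Homo sapiens) for cytotoxicity, read by MTT assay, with a stated time of 48 h (a lower number here means a stronger inhibitor, a higher number a weaker inhibitor), compound 3 `O=c1ccoc2cc(OCc3cn(Cc4ccc(Cl)cc4)nn3)ccc12` gives > 100000 nM, which is a limit and not a number. Compound 1 `O=c1ccoc2cc(OCc3cn(Cc4ccccc4)nn3)ccc12` gives > 100000 nM, which is also a limit. The small set therefore holds (the limit of > 100000 nM in this assay, at which 2 of the 3 values shown sit). Only compound 2 `Cc1cccc(Cn2cc(COc3ccc4c(=O)ccoc4c3)nn2)c1` has a true number, at 16000 nM.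

Compound 4 `O=c1ccoc2cc(OCc3cn(Cc4cccc(F)c4)nn3)ccc12` carries 3-fluorophenyl in place of 4-chlorophenyl on a saturated chain carbon bound to an aromatic nitrogen. Among the measured compounds shown here, three measured steps bear on this change. Methyl in place of hydrogen gave an at least 6.2-fold lower number from compound 1 to compound 2 (0.79 log units; beyond the scatter). Chloro in place of hydrogen gave a step that the two limits leave unreadable from compound 1 to compound 3. Replacing 3-methylphenyl with 4-chlorophenyl gave an at least 6.2-fold higher number from compound 2 to compound 3 (0.79 log units; beyond the scatter).

So the one compound with a true number carries a 3-substituted phenyl, as compound 4 does, while the unsubstituted compound 1 and the 4-chlorophenyl compound 3 both stay at the limit. For the measured compounds named here, that is thin support, since fluoro is not methyl and only one compound points this way. In this assay a modest fall in the number is expected, although compound 4 may well remain at the limit. The expected change is an at least 2.0-fold lower number from compound 3 to compound 4 (0.30 log units; that floor lies within the scatter). For compound 4 the estimated value is 50000 nM, with an expected range of 15000 nM to 100000 nM.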

Compound 4, half-maximal inhibitory concentration: > 100000 nM
Compound 4: only a limit was reported (the forecaster's own chance of this, stated with the estimate: 50%); at least 2.0-fold (0.30 log units) between middle value and limit.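

In this assay, fluoro in place of methyl on an aromatic carbon gives an at least 6.2-fold higher number from compound 2 to compound 4 (0.79 log units; beyond the scatter), so the 3-fluorophenyl group does not keep the measurable activity seen with 3-methylphenyl. Before this result, compound 2 could be read as a sign that any substituent at this place on the ring might bring a true number, but compound 4 goes against that reading, and among the compounds shown only 3-methylphenyl gives one. The steps linking compound 4 with compound 1 and compound 3 cannot be read, because a limit stands at both ends of each, so no order among these three compounds can be given: the limit of > 100000 nM in this assay, at which 3 of the 4 values shown sit.

The compounds shown leave open whether the effect belongs to methyl in particular or would also appear with a similar group such as ethyl, methoxy or 3-chlorophenyl in place of 3-methylphenyl. They also leave open whether an amine or a carboxylic acid on the phenyl ring would bring the number down from the limit, and how far any such number would fall.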